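This account rests on a few compounds, and the source may have more. Where it says the series, first, only, none or still open, it means among the compounds named here.

Compound 1 `COc1cc(-c2cc(/C=C/C(=O)c3ccc(N)cc3)[nH]n2)cc(OC)c1OC` was tested in a functional assay on K562 cells (Homo sapiens) for cytotoxicity, read by sulforhodamine B assay, with a stated time of 48 h, tested at 0.1 uM (on this read-out lower numbers stand for a stronger effect and higher numbers for a weaker effect at the one concentration tested), and gave 94%. Compound 2 `COc1ccc(C(=O)/C=C/c2cc(-c3cc(OC)c(OC)c(OC)c3)n[nH]2)cc1` gave 102% in this assay, and the step of a number 8 percentage points higher from compound 1 to compound 2 (within the scatter) came with a methoxy in place of an amino group on an aromatic carbon. Compound 1 thus holds the lower of the two numbers recorded, but its gap to compound 2 lies within the scatter, so neither can be called the stronger. Compound 3 `COc1cc(-c2cc(/C=C/C(=O)c3ccc(F)c(F)c3)[nH]n2)cc(OC)c1OC` has not yet been measured; it differs from compound 1 by 3,4-difluorophenyl in place of 4-aminophenyl on a carbonyl carbon. Going by the values given here, no measured step exchanges the 4-aminophenyl for another aryl group, and the only step at hand, amino to methoxy, stayed within the scatter. The account therefore expects no step beyond the scatter for compound 3 in this assay, namely a number 1 percentage points higher from compound 1 to compound 3 (within the scatter). Compound 3 is estimated at 95%, with a range from 78% to 110%.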

Compound 3, a percentage reported as activity, at one concentration (the size of the read-out at that concentration, not a potency): 109%
For compound 3 the middle estimate is 14 percentage points below the measured one, and the stated range covers the measured number.
By their numbers in this assay, from the lowest: compounds 1, 2 and 3 (each within the scatter of the next, the first and the last beyond it).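

Going by these compounds alone, at the carbonyl carbon, the exchange of 4-aminophenyl for 3,4-difluorophenyl gives the first step beyond the scatter in this assay, a weaker effect at the one concentration tested (a number 15 percentage points higher from compound 1 to compound 3 (beyond the scatter)). The same group in place of 4-methoxyphenyl stays within the scatter (a number 7 percentage points higher from compound 2 to compound 3 (within the scatter)), so the aryl group on this carbon can shift the read-out, but only the two compounds furthest apart are separated, and compound 2 cannot be told from either. Nothing available accounts for this step.

Going by these compounds, whether a 4-hydroxyphenyl or a 4-dimethylaminophenyl on the carbonyl carbon would fall with compound 1 or with compound 3 remains open. So does how far these aryl groups would separate at other concentrations, since a single concentration gives no potency.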